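Turning the amide around on the core of compound 2

The compounds below may be only part of what the source reports. "The series", "measured", "known", "first", "only" and "open" are said of these compounds alone.

Compound 2 `CCC(C)CNC(=O)c1ccc2c(c1)c(Cc1ccc(C(=O)NS(=O)(=O)c3ccccc3C)cc1OC)cn2C` gives 8.7 in an assay on isolated protein for binding affinity to cysteinyl leukotriene receptor 1 (Cavia porcellus); a lower number here means a less potent compound, a higher number a more potent compound, by a factor of ten per unit of this negative logarithm. Among the compounds with values here, its only measured companion, compound 1 `COc1cc(C(=O)NS(=O)(=O)c2ccccc2C)ccc1Cc1cn(C)c2ccc(C(=O)NCC(C)C)cc12`, gives 8.6 in this assay, and the two values lie within the scatter of each other, the sole measured step being a number 0.10 log units higher from compound 1 to compound 2 (within the scatter). Compound 3 `COc1cc(C(=O)NS(=O)(=O)c2ccccc2C)ccc1Cc1cn(C)c2ccc(NC(=O)CC3CCCC3)cc12` carries a change of a different kind: ((cyclopentylmethyl)carbonyl)amino in place of (2-methylbutyl)carbamoyl on an aromatic carbon. Within the data shown here, the one measured step concerns a methyl on a saturated chain and leaves the amide-type group and its orientation untouched, so no measured step bears directly on this change. Among the measured compounds shown here, the groups that leave and enter match in their counts of hydrogen-bond donors and acceptors and in the single double bond outside aromatic rings, which is the only ground for comparison available. For the measured compounds named here, with no direct precedent, a step within the scatter in either direction is expected, and the range is set wide to reflect the untested reversal. Compound 3 is therefore expected to give 8.3 in this assay, between 7.5 and 9, the expected step being a number 0.40 log units lower from compound 2 to compound 3 (beyond the scatter).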

Compound 3, negative logarithm of the antagonist equilibrium constant: 9.7
Compound 3: the middle estimate sits 1.40 log units below what was measured; measured number outside the range, above it.
By their numbers in this assay, from the lowest: compounds 1 and 2 (each within the scatter of the next); then compound 3.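

In this assay, the group on this aromatic carbon turns out to matter far more than the earlier pair could show: compounds 1 and 2 differ only by a methyl on the saturated chain, with a number 0.10 log units higher from compound 1 to compound 2 (within the scatter), whereas ((cyclopentylmethyl)carbonyl)amino in place of (2-methylbutyl)carbamoyl gives a number 1.00 log units higher from compound 2 to compound 3 (beyond the scatter). The same entering group in place of isobutylcarbamoyl gives a number 1.10 log units higher from compound 1 to compound 3 (beyond the scatter), so compound 3 stands beyond the scatter of both carbamoyl compounds and is the highest of the three. No measurement here offers an explanation for this gain.

The change reverses the amide and also replaces the open chain with a five-membered non-aromatic ring of carbon only, so the compounds shown cannot divide the gain between these two differences. As far as these compounds go, that division would need either (cyclopentylmethyl)carbamoyl on the same aromatic carbon or a reversed amide carrying an open chain such as 2-methylbutyl, and whether a cyclohexyl ring would serve as well as the cyclopentyl ring also remains open.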